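This account rests on a few compounds, and the source may have more. Where it says the series, first, only, none or still open, it means among the compounds named here.

Compound 3, `CC(C)N1CCN(CCN2CCC(c3c[nH]c4cc(Cl)ccc34)CC2)C1=O`, gives 34 nM in an assay on cell membranes for displacement of a labelled ligand from Adrenergic receptor alpha-1 (Rattus norvegicus); on this read-out higher numbers stand for weaker inhibition and lower numbers for stronger inhibition. Among the three measured compounds it holds the highest number. Compound 2, `Cc1ccc2c(C3CCN(CCN4CCN(C(C)C)C4=O)CC3)c[nH]c2c1`, gives 27 nM, and the step of a 1.3-fold higher number from compound 2 to compound 3 (0.10 log units; within the scatter) lies within the scatter, so the two cannot be told apart. Compound 1, `O=C1NCCN1CCN1CCC(c2cn(-c3ccc(F)cc3)c3cc(F)ccc23)CC1`, gives 2.2 nM, a lower number that lies beyond the scatter.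

Compound 4, `CC(C)N1CCN(CCN2CCC(c3cn(-c4ccccc4)c4cc(Cl)ccc34)CC2)C1=O`, differs from compound 3 in one place: phenyl in place of hydrogen on an aromatic nitrogen. Among the compounds with values here, no measured pair differs by this change alone. Within the data shown here, the only measured step, from compound 2 to compound 3, swaps one group on an aromatic carbon for another and is within the scatter, so it says nothing about a group placed on the aromatic nitrogen. Compound 1 carries an aromatic ring on that nitrogen, but it also differs from compound 3 elsewhere, so its value is only a weak hint toward a lower number.

Compound 4 is therefore expected to show a modest step down, a 2.8-fold lower number from compound 3 to compound 4 (0.45 log units; beyond the scatter), and is estimated at 12 nM, with a range from 3 nM to 45 nM.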

Compound 4, half-maximal inhibitory concentration: 39 nM
Compound 4: middle estimate off by 3.3-fold (0.51 log units), on the low side; the range from low to high includes it.
By their numbers in this assay, from the lowest: compound 1; then compounds 2, 3 and 4 (each within the scatter of the next).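

In this assay, phenyl in place of hydrogen on the aromatic nitrogen gives a 1.1-fold higher number from compound 3 to compound 4 (0.06 log units; within the scatter) and so leaves compound 3 and compound 4 indistinguishable. Within the data shown here, this is the first direct reading of this change, and it shows that the position can carry a six-membered aromatic ring with no measurable shift in the number, whereas compound 1 differs from compound 3 in more than one place and could only hint at the effect. Nothing available explains this result.

As far as these compounds go, whether a different group on that nitrogen, such as methyl, a carboxylic acid or a longer chain ending in an amine, would move the number beyond the scatter remains open. From the compounds shown here alone, it is also open whether phenyl would give the same result with methyl in place of chloro on the shared core.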